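Ring heteroatom swap at the sulfonylmethyl side chain

The source may report more compounds than this note shows. Statements on the series, on what has been measured and on what is new or still open speak of the compounds shown alone.

The series gathers two measured compounds and one still to be measured, all sharing a sulfonyl group that carries a saturated chain carbon bearing a five-membered non-aromatic ring. Compound 1 `Cc1ccc(-c2c[nH]nc2S(=O)(=O)CC2=NCCS2)cc1` was tested in a functional assay, tested at 100 ug/mL (on this read-out lower numbers stand for a weaker effect and higher numbers for a stronger effect at the one concentration tested), and compound 1 was reported as "not active" (no number reported), with no number given. Compound 2 `COc1ccc(-c2noc(-c3ccc(C)cc3)c2S(=O)(=O)CC2=NCCO2)cc1` is the only entry with a figure: in this assay compound 2 reaches 77.1%. Going by the values given here, since compound 1 differs from compound 2 in more than one place, the two values show only that one compound was inactive and the other clearly active, and nothing about any single change.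

Compound 3 `COc1ccc(-c2noc(-c3ccc(C)cc3)c2S(=O)(=O)CC2=NCCS2)cc1` differs from compound 2 in one place: a group of 5 heavy atoms (3 carbon, 1 nitrogen, 1 sulfur; one five-membered non-aromatic ring with 2 hetero atoms) in place of a group of 5 heavy atoms (3 carbon, 1 nitrogen, 1 oxygen; one five-membered non-aromatic ring with 2 hetero atoms), on a saturated chain carbon bound to a sulfonyl sulfur. Among the compounds with values here, no measured step of this kind exists in the set, so the size of the change in this assay is open. The inactivity of compound 1, which carries the same entering ring on a different core, gives only a faint hint. A modest loss is expected, with a number 15.1 percentage points lower from compound 2 to compound 3 (beyond the scatter) as the estimated step from compound 2 to compound 3. Compound 3 is expected to give 62%, within a range of 30% to 85%.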

Compound 3, a percentage reported as activity, at one concentration (the size of the read-out at that concentration, not a potency): "not active" (no number reported)
Nothing numeric was reported for compound 3, so the estimate cannot be set against anything.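

In this assay, going by these compounds alone, compound 3 carries no number, so no step from compound 2 to compound 3 can be read. No measurement shown bears on this result. The compounds shown leave open how large a change the five-membered ring with sulfur brings in place of the five-membered ring with oxygen.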